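Amine Variations on a Propoxy Chain, Then a Phenyl

This account rests on a few compounds, and the source may have more. Where it says the series, first, only, none or still open, it means among the compounds named here.

Measured in a functional assay on A549 cells (Homo sapiens) for antiproliferative activity, read by MTT assay, with a stated time of 72 h; on this read-out higher numbers stand for weaker inhibition and lower numbers for stronger inhibition:
Compound 1 `COc1cc2c(Nc3ccc(C#N)cc3)ncnc2cc1OCCCN(C)C`: 60500 nM
Compound 2 `COc1cc2c(Nc3ccc(C#N)cc3)ncnc2cc1OCCCN1CCCC1`: 21800 nM
Compound 3 `COc1cc2c(Nc3ccc(C#N)cc3)ncnc2cc1OCCCN1CCC(O)CC1`: 29900 nM

Compound 3 gives a number lower than compound 1, as a 2.0-fold lower number from compound 1 to compound 3 (0.31 log units; beyond the scatter) shows, and one within the scatter of compound 2, as a 1.4-fold higher number from compound 2 to compound 3 (0.14 log units; within the scatter) shows. Compound 4 `COc1cc2c(Nc3ccc(C#N)cc3)ncnc2cc1OCCCN1CCC(c2ccccc2)CC1` differs from compound 3 by phenyl in place of hydroxy on a saturated ring carbon. For the measured compounds named here, no measured step exchanges a hydroxy for a phenyl. The steps that touch this amine are a 2.8-fold lower number from compound 1 to compound 2 (0.44 log units; beyond the scatter) and a 2.0-fold lower number from compound 1 to compound 3 (0.31 log units; beyond the scatter), both modest, while a 1.4-fold higher number from compound 2 to compound 3 (0.14 log units; within the scatter) stays within the scatter. Compound 4 is therefore expected to land near compound 3 or modestly lower in this assay, a 2.0-fold lower number from compound 3 to compound 4 (0.30 log units; within the scatter). The estimate for compound 4 is 15000 nM, with a range from 5000 nM to 45000 nM.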

Compound 4, half-maximal inhibitory concentration: 9500 nM
The estimate for compound 4 lay 1.6-fold (0.20 log units) above the measured number; low and high end bracket the measured number.
By their numbers in this assay, from the lowest: compound 4; then compounds 2 and 3 (each within the scatter of the next); then compound 1.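

In this assay, exchanging hydroxy for phenyl on this saturated ring carbon gives a 3.1-fold lower number from compound 3 to compound 4 (0.50 log units; beyond the scatter), so the position takes six heavy atoms in place of one with no loss, and the number falls beyond the scatter. The 4-phenylpiperidin-1-yl amine also stands apart from the two smaller amines, with a 2.3-fold lower number from compound 2 to compound 4 (0.36 log units; beyond the scatter) and a 6.4-fold lower number from compound 1 to compound 4 (0.80 log units; beyond the scatter). Nothing available here explains this step.

On these data alone, it remains open whether a benzyl group or a pyridine ring on the same ring carbon would lower the number further. As far as these compounds go, the effect of a longer chain between the oxygen and the amine also remains open.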